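Cytotoxicity of a Shared Core: Replacing the Pyrrolidine Amine

The source may hold more compounds than are shown below. What is called first, only, known or untested is meant among the compounds shown, and "the series" means these compounds.

Measured compounds:
- Compound 1, `Cn1c(-c2ccc([N+](=O)[O-])cc2)nc2cc(C(F)(F)F)ccc21`: >= 100000 nM
- Compound 2, `Cn1c(-c2ccc(NC(=O)CN3CCCC3)cc2)nc2cc(C(F)(F)F)ccc21`: 16000 nM
- Compound 3, `Cn1c(-c2ccc(N)cc2)nc2cc(C(F)(F)F)ccc21`: 20000 nM

In an ADME assay on MT4 cells (Homo sapiens) for cytotoxicity, read by MTT assay, with a stated time of 96 h (a higher number here means that more compound is tolerated, a lower number that less compound is tolerated), compound 1 reaches only a limit, >= 100000 nM. Compound 2 gives 16000 nM, the lowest of the two true numbers, and compound 3 sits within the scatter of it: a 1.3-fold higher number from compound 2 to compound 3 (0.10 log units; within the scatter). The steps away from compound 1 are larger: an at least 6.2-fold lower number from compound 1 to compound 2 (0.79 log units; beyond the scatter) and an at least 5.0-fold lower number from compound 1 to compound 3 (0.69 log units; beyond the scatter).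

Compound 4, `Cn1c(-c2ccc(NC(=O)CN3CCN(c4ccccc4)CC3)cc2)nc2cc(C(F)(F)F)ccc21`, differs from compound 2 at the amine end of the side chain: 4-phenylpiperazin-1-yl in place of pyrrolidin-1-yl on a saturated chain carbon bound to a carbonyl carbon. Going by the values given here, no measured step alters this part of the chain alone; the nearest, removing the whole acyl group, stayed within the scatter. No step beyond the scatter is therefore expected, and compound 4 is estimated at 12000 nM, between 4000 nM and 32000 nM, meaning a 1.3-fold lower number from compound 2 to compound 4 (0.12 log units; within the scatter).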

Compound 4, half-maximal cytotoxic concentration: 1500 nM
For compound 4 the middle estimate is 8.0-fold (0.90 log units) above the measured one; the measured number lies below the stated range.
By their numbers in this assay, from the lowest: compound 4; then compounds 2 and 3 (each within the scatter of the next). At a limit, above all of these: compound 1.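

In this assay there is an 11-fold lower number from compound 2 to compound 4 (1.03 log units; beyond the scatter) when 4-phenylpiperazin-1-yl replaces pyrrolidin-1-yl on the side chain. Compound 2 and compound 3 stayed within the scatter of each other, so only compound 4 shows that the amine end of this chain can lower the number. Nothing measured here gives a cause for this step.

The compounds shown leave open whether the phenyl ring or the piperazine ring accounts for the change. A piperazine carrying a methyl group instead of the phenyl, or a piperidine carrying the phenyl, would help separate the two.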